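Removing a Methoxy Group: What It Does to Solubility

A few compounds are considered here, and "the series" means these few. Any claim that something is new, unique, unknown or untested is made for them only; others in the source may bear on it.

The measured compounds and their values:

compound 1, `COc1cc(OC)cc(OCC(=O)O)c1`: 171000 ug/mL
compound 2, `COc1cc(OCC(=O)O)cc(OC)c1OC`: 171000 ug/mL
compound 3, `COc1cc(COCC(=O)O)ccc1C`: 183000 ug/mL

All three were measured in an ADME assay (Homo sapiens) for solubility; on this read-out higher numbers stand for higher solubility and lower numbers for lower solubility. Compound 2 and compound 1 differ in one place only: hydrogen in place of methoxy on an aromatic carbon. The step this made, no change at the digits printed from compound 2 to compound 1 (within the scatter), shows that taking this methoxy group away left the read-out where it was. Compound 3 sits together with compound 1 and compound 2; its gaps to both lie within the scatter, so no order among the three can be read from these numbers. How the core of compound 3 differs from the core of compound 2 is not broken down here.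

Compound 4, `Cc1ccc(COCC(=O)O)cc1`, has not yet been measured. It differs from compound 3 in one place: hydrogen in place of methoxy on an aromatic carbon. Among the compounds with values here, this is the same kind of change as the one from compound 2 to compound 1, but not the same: in compound 2 the carbon carrying the methoxy group is ortho to two methoxy groups and para to a carboxymethoxy group, while in compound 3 it is ortho to a methyl group and meta to a group of 6 heavy atoms.

Because the earlier step of no change at the digits printed from compound 2 to compound 1 (within the scatter) was flat, the step of a 1.0-fold lower number from compound 3 to compound 4 (0.01 log units; within the scatter) is expected to be small as well. Compound 4 is therefore estimated at 180000 ug/mL, with a range from 100000 ug/mL to 300000 ug/mL.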

Compound 4, solubility: 174000 ug/mL
For compound 4 the middle estimate is 1.0-fold (0.01 log units) above the measured one, and the stated range covers the measured number.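

Replacing methoxy with hydrogen on an aromatic carbon gave a 1.1-fold lower number from compound 3 to compound 4 (0.02 log units; within the scatter), so the second core gives the same flat picture as the first. Set side by side in this assay, the two steps agree: the same change on two cores in this assay, no change at the digits printed (within the scatter) from compound 2 to compound 1 and a 1.1-fold lower number (0.02 log units; within the scatter) from compound 3 to compound 4, 1.1-fold (0.02 log units) apart, within the scatter of two such steps

This means that, on these two cores, the step seen on one core would have been a fair guide to the step on the other, even though the carbon losing the methoxy group has different neighbours in each. It does not show that the same swap would stay flat on every core in the series, since two pairs are a small sample, and a flat step by itself gives no reason why nothing moved.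

The compounds shown leave open what would happen on a core carrying an amine, or with a longer chain joining the aromatic ring to the carboxylic acid that all four compounds share. They also leave open whether a change other than hydrogen in place of methoxy, such as a fluorine atom in that place, would stay just as flat.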